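Replacing furan-2-yl with 2-fluoropyridin-4-yl: outlook for compound 4

The compounds below may be only part of what the source reports. "The series", "measured", "known", "first", "only" and "open" are said of these compounds alone.

Measured so far, in an in vitro functional assay on HEK285-7 cells for antagonist activity at prostaglandin D2 receptor 2 (Homo sapiens), read by BRET and beta-arrestin recruitment; on this read-out higher numbers stand for weaker inhibition and lower numbers for stronger inhibition:
compound 1 `N#Cc1ccc(-c2nc(C(c3ccc(F)cc3)c3ccc(F)cc3)sc2CC(=O)O)cc1` gives 1500 nM
compound 2 `NS(=O)(=O)c1cccc(-c2nc(C(c3ccc(F)cc3)c3ccc(F)cc3)sc2CC(=O)O)c1` gives 710 nM
compound 3 `O=C(O)Cc1sc(C(c2ccc(F)cc2)c2ccc(F)cc2)nc1-c1ccco1` gives 140 nM

All three share the same core and differ only in the aromatic group on the five-membered aromatic ring with 1 nitrogen and 1 sulfur. On the numbers shown, compound 3 stands lowest of the three; its nearest neighbour is compound 2, and compound 1 lies furthest from it, both gaps beyond the scatter.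

Compound 4 `O=C(O)Cc1sc(C(c2ccc(F)cc2)c2ccc(F)cc2)nc1-c1ccnc(F)c1` is the next variation on this position: 2-fluoropyridin-4-yl in place of furan-2-yl on an aromatic carbon. Among the measured compounds shown here, two measured steps bear on it, both running from a six-membered aryl to furan-2-yl: an 11-fold lower number from compound 1 to compound 3 (1.03 log units; beyond the scatter) and a 5.1-fold lower number from compound 2 to compound 3 (0.71 log units; beyond the scatter). The third step, a 2.1-fold lower number from compound 1 to compound 2 (0.32 log units; beyond the scatter), shows that the two six-membered aryls differ from each other only modestly. Compound 4 reverses the direction of the two larger steps, moving back from the five-membered furan-2-yl to a six-membered ring, so in this assay the expected step is an increase, roughly in the range spanned by those two steps.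

For compound 4 the estimate in this assay is 450 nM, with a range of 150 nM to 1500 nM, corresponding to an expected step of a 3.2-fold higher number from compound 3 to compound 4 (0.51 log units; beyond the scatter).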

Compound 4, half-maximal inhibitory concentration: 4.7 nM
Beside the measured number, compound 4's estimate is 96-fold (1.98 log units) above it; measured number below the stated range.
By their numbers in this assay, from the lowest: compound 4; then compound 3; then compound 2; then compound 1.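

In this assay, among the compounds shown here, 2-fluoropyridin-4-yl gives a 30-fold lower number from compound 3 to compound 4 (1.47 log units; beyond the scatter), so at this position a six-membered aromatic ring is not in itself worse than furan-2-yl, and compound 4 goes against the order seen in the earlier compounds. The gaps to the other two six-membered aryls are wider, at a 150-fold lower number from compound 2 to compound 4 (2.18 log units; beyond the scatter) and a 320-fold lower number from compound 1 to compound 4 (2.50 log units; beyond the scatter), and both far exceed a 2.1-fold lower number from compound 1 to compound 2 (0.32 log units; beyond the scatter), showing that the choice of six-membered ring can matter much more than that earlier step suggested. No measurement available here accounts for this gain.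

The compounds shown do not separate the part played by the ring nitrogen of 2-fluoropyridin-4-yl from that of its fluorine, and an unsubstituted pyridin-4-yl and a phenyl bearing a single fluorine, each set against compound 4, would address that question. As far as these compounds go, it also remains open whether a chlorine, a methyl or a methoxy group in place of that fluorine would keep the number near that of compound 4 at 4.7 nM.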